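Ring amine change on the shared core: compound 3 to compound 4

The source may hold more compounds than are shown below. What is called first, only, known or untested is meant among the compounds shown, and "the series" means these compounds.

Values in a functional assay on MCF7 cells (Homo sapiens) for inhibition, read by sulforhodamine B assay; on this read-out lower numbers stand for stronger inhibition and higher numbers for weaker inhibition:
- compound 1 `CCOc1ccc(NC2=CC(=O)c3c(nc4n3[C@H]3OC[C@@H](O)[C@H]3OC4)C2=O)cc1`: > 4000 nM
- compound 2 `O=C1C=C(Nc2ccc(C(F)(F)F)cc2)C(=O)c2c1nc1n2[C@H]2OC[C@@H](O)[C@H]2OC1`: > 4000 nM
- compound 3 `O=C1C=C(NC2CCCC2)C(=O)c2c1nc1n2[C@H]2OC[C@@H](O)[C@H]2OC1`: > 16000 nM

The value of compound 1 is a limit of the assay, not a number. The value of compound 2 is likewise a limit. The value of compound 3 is also a limit, and it sits at the limit of > 16000 nM in this assay, at which 1 of the 3 values shown sits. The other two values of the series sit at the limit of > 4000 nM in this assay, at which 2 of the 3 values shown sit. Compound 3 therefore stands at the upper limit among the three values, with no number of its own. Going by the values given here, the only step between measured compounds that differ in one place, a step that the two limits leave unreadable from compound 2 to compound 3, cannot be read in size.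

Compound 4 `O=C1C=C(N2CCCC2)C(=O)c2c1nc1n2[C@H]2OC[C@@H](O)[C@H]2OC1` differs from compound 3 in pyrrolidin-1-yl in place of cyclopentylamino on a double-bonded ring carbon. Among the compounds with values here, no measured step bears readably on this change, and all three values are limits, so no step beyond the scatter can be predicted in this assay in either direction. Compound 4 is expected to give about 20000 nM in this assay, most probably again as a limit rather than a number. The expected range for compound 4 runs from 5000 nM to 80000 nM. The step this estimate implies, a step that the limit leaves unreadable from compound 3 to compound 4, is expected to stay within the scatter.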

Compound 4, half-maximal inhibitory concentration: > 16000 nM
Compound 4 ended at the assay's limit (the forecaster's own chance of this, stated with the estimate: 85%); the middle value does not contradict the limit.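

In this assay, going by these compounds alone, compound 3 and compound 4 both stand at a limit and not at a number, and no step between them can be read. The compounds shown leave open whether any amine on the shared core gives a measurable number in this assay.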